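This account rests on a few compounds, and the source may have more. Where it says the series, first, only, none or still open, it means among the compounds named here.

Measured compounds in a functional assay on HCT-15 cells (Homo sapiens) for inhibition, read by sulforhodamine B assay, with a stated time of 48 h; on this read-out lower numbers stand for stronger inhibition of growth and higher numbers for weaker inhibition of growth:

compound 1 `COc1cc(-c2nn(-c3cccc(NC(=O)Nc4cc(C(F)(F)F)cc(C(F)(F)F)c4)c3)cc2-c2ccncc2)ccc1Cl`: 617 nM
compound 2 `COc1cc(-c2nn(-c3cccc(NC(=O)Nc4ccc(Cl)c(Cl)c4)c3)cc2-c2ccncc2)ccc1Cl`: 1230 nM

Within the data shown here, compound 1 stands lowest of the two numbers in this assay, but its only neighbour, compound 2, lies within the usual scatter of repeated measurements, so the two values cannot be ordered. Compound 3 `COc1cc(-c2nn(-c3cccc(NC(=O)Nc4cccc(C(F)(F)F)c4)c3)cc2-c2ccncc2)ccc1Cl` has not yet been measured. It differs from compound 1 in one place: hydrogen in place of trifluoromethyl on an aromatic carbon. The change sits on an aromatic carbon of a six-membered aromatic ring of carbon only, meta to a large group and meta to a trifluoromethyl group. Among the measured compounds shown here, no pair of measured compounds shows this kind of step, so its size cannot be read from the data. Removing one trifluoromethyl is expected to cost little, with compound 3 expected to land near compound 2 rather than far from compound 1: a step of a 1.6-fold higher number from compound 1 to compound 3 (0.21 log units; within the scatter), estimated at 1000 nM with a range of 400 nM to 2500 nM.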

Compound 3, concentration for 50% growth inhibition: 870 nM
For compound 3 the middle estimate is 1.1-fold (0.06 log units) above the measured one, within the range that was stated.
By their numbers in this assay, from the lowest: compounds 1, 3 and 2 (each within the scatter of the next).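

In this assay, hydrogen in place of one trifluoromethyl gives a 1.4-fold higher number from compound 1 to compound 3 (0.15 log units; within the scatter). So at this position, meta to a large group and meta to a trifluoromethyl group, this first direct test of the change shows no difference that can be told from scatter. The exchange of 3,4-dichlorophenyl for 3-(trifluoromethyl)phenyl gives a 1.4-fold lower number from compound 2 to compound 3 (0.15 log units; within the scatter), which leaves compound 3 indistinguishable from both of the compounds it can be compared with. Nothing measured here bears on a cause for these steps.

Going by these compounds, what remains open is whether another group at this position, such as an amine, a methoxy group or a carboxylic acid, would give a step beyond the scatter in this assay. On these data alone, it is also open whether removing the remaining trifluoromethyl of compound 3 would do so.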